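This account rests on a few compounds, and the source may have more. Where it says the series, first, only, none or still open, it means among the compounds named here.

Compound 3 `CCC(/C=C(\COC(C)=O)C(=O)c1ccccc1)CC` was tested in a functional assay on HBL-100 cells (Homo sapiens) for inhibition, read by sulforhodamine B assay, with a stated time of 48 h; a higher number here means a weaker inhibitor of growth, a lower number a stronger inhibitor of growth. For compound 3 the result is only a limit, > 100000 nM, not a number. That places it at the edge of what was measured, as the limit of > 100000 nM in this assay, at which 1 of the 3 values shown sits, records. Two related compounds give numbers: compound 1 `O=C(/C(=C/C1CCCCC1)CCl)c1ccccc1` gives 22000 nM in this assay, and compound 2 `O=C(/C(=C/c1ccc(Cl)cc1Cl)CCl)c1ccccc1` gives 3100 nM. Compound 4 `CC(=O)OC/C(=C\c1ccc(Cl)cc1)C(=O)c1ccccc1` differs from compound 3 by 4-chlorophenyl in place of pentan-3-yl on a double-bonded chain carbon bound to a double-bonded chain carbon. For the measured compounds named here, no measured pair shows this exact swap, so the size of the step can only be estimated. The step expected in this assay is an at least 5.0-fold lower number from compound 3 to compound 4 (0.69 log units; beyond the scatter), in the direction of stronger growth inhibition. Compound 4 is therefore expected to give 20000 nM, with a range from 4000 nM to 100000 nM.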

Compound 4, concentration for 50% growth inhibition: 2300 nM
Compound 4: middle estimate off by 8.7-fold (0.94 log units), on the high side; measured number outside the range, below it.
By their numbers in this assay, from the lowest: compounds 4 and 2 (each within the scatter of the next); then compound 1. At a limit, above all of these: compound 3.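

Putting 4-chlorophenyl in place of pentan-3-yl on this double-bonded chain carbon gives an at least 43-fold lower number from compound 3 to compound 4 (1.63 log units; beyond the scatter) in this assay. For the compounds shown here, this is the first single change with a measured step here, and it shows that growth inhibition responds strongly to the group at this position. The full size of the step cannot be read, because compound 3 has only a limit: the limit of > 100000 nM in this assay, at which 1 of the 4 values shown sits.

Whether the ring or its chlorine accounts for the step stays open, and a plain phenyl at this place would help separate the two. Going by these compounds, how an amine on that ring would read in this assay also stays open.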